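A few compounds are considered here, and "the series" means these few. Any claim that something is new, unique, unknown or untested is made for them only; others in the source may bear on it.

Measured compounds:
- Compound 1 `NCc1cccc(C2CCN(C(=O)c3ccc(O)c(O)c3)CC2)c1` — 2310 nM
- Compound 2 `COc1cc(C(=O)N2CCC(c3cccc(CN)c3)CC2)cc(O)c1O` — 7430 nM

Compound 1 has the lowest of the two numbers in an assay on isolated protein for inhibition of tryptase beta-2 (Mus musculus), with stated times of 3 h, 30 s and 15 min; on this read-out lower numbers stand for stronger inhibition and higher numbers for weaker inhibition. Among the measured compounds shown here, compound 2 sits at the other end: the single measured step shows a 3.2-fold higher number from compound 1 to compound 2 (0.51 log units; beyond the scatter), brought about by a methoxy in place of hydrogen on an aromatic carbon of the shared core.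

Compound 3 `CONC(=O)c1cc(C(=O)N2CCC(c3cccc(CN)c3)CC2)ccc1O` is the unmeasured member of the set. Relative to compound 1 it carries methoxycarbamoyl in place of hydroxy on an aromatic carbon, that is, methoxycarbamoyl in place of hydroxy on an aromatic carbon, ortho to a hydroxy group and meta to a large group. For the measured compounds named here, no measured pair covers this exact change. Going by the values given here, the only step that bears on it at all is the one from compound 1 to compound 2, where a new group on the same ring gave a modest rise beyond the scatter. A rise of similar or somewhat larger size is therefore expected here, a 2.8-fold higher number from compound 1 to compound 3 (0.45 log units; beyond the scatter). On that basis compound 3 is estimated at 6500 nM in this assay, with a range of 2000 nM to 20000 nM.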

Compound 3, half-maximal inhibitory concentration: 455 nM
Compound 3: middle estimate off by 14-fold (1.15 log units), on the high side; the whole stated range lies above it.
By their numbers in this assay, from the lowest: compound 3; then compound 1; then compound 2.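

In this assay, the hydroxy ortho to a hydroxy group and meta to a large group proves replaceable: exchanging it for methoxycarbamoyl, five heavy atoms in place of one, gives a 5.1-fold lower number from compound 1 to compound 3 (0.71 log units; beyond the scatter). Among the compounds shown here, the only earlier step, a 3.2-fold higher number from compound 1 to compound 2 (0.51 log units; beyond the scatter), went the other way, but it put a methoxy in place of a hydrogen on the ring instead of replacing a hydroxy, so a rise on adding a group at one place on this ring did not carry over to this change at this place; the two steps together show that the outcome on this ring depends on the place and the group involved, and they are only two steps. Nothing available accounts for the lower number, and no measurement on hand gives a reason for it.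

The compounds shown leave open which part of the methoxycarbamoyl group goes with the lower number, since a plain carboxamide, a carboxylic acid or an ethoxycarbamoyl group at this place does not appear among them. For the compounds shown here, they also leave open whether the remaining hydroxy contributes, as no compound here carries methoxycarbamoyl with a methoxy or a hydrogen in that hydroxy's place.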